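Methyl in Place of Methoxy: What to Expect for Compound 4

The compounds below may be only part of what the source reports. "The series", "measured", "known", "first", "only" and "open" are said of these compounds alone.

compound 1 `COc1ccc(-c2cn(C[C@H]3c4c(ccc(O)c4C)[C@@H]4CC[C@@]5(C)C[C@]43CC5=O)nn2)cc1` — > 20000 nM
compound 2 `Cc1ccc(S(=O)(=O)Oc2ccc3c(c2C)[C@H](Cn2cc(-c4ccc(C(F)(F)F)cc4)nn2)[C@@]24CC(=O)[C@@](C)(CC[C@@H]32)C4)cc1` — > 20000 nM
compound 3 `C=C1C[C@]23C[C@@]1(O)CC[C@@H]2c1cccc(C)c1[C@@H]3Cn1cc(-c2ccc(F)cc2)nn1` — > 20000 nM

Of the compounds shown here, three have been tested in a functional assay on SMMC-7721 cells (Homo sapiens) for cytotoxicity, read by MTT assay, with a stated time of 4 days; a higher number here means a weaker inhibitor, a lower number a stronger inhibitor. Compound 1 gives > 20000 nM, which is a limit of the assay and not a number. Compound 2 also stops at a limit, > 20000 nM. Compound 3 likewise gives a limit, > 20000 nM. Compound 1 therefore stands exactly where the other two stand, at the limit of > 20000 nM in this assay, at which 3 of the 3 values shown sit. For the measured compounds named here, no step between measured compounds is available, since all three are limits and differ from one another in more than one place, so no size of change can be read from them.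

Compound 4 `Cc1ccc(-c2cn(C[C@H]3c4c(ccc(O)c4C)[C@@H]4CC[C@@]5(C)C[C@]43CC5=O)nn2)cc1` differs from compound 1 in a single place: methyl in place of methoxy on an aromatic carbon. Compound 1 itself shows only a limit, > 20000 nM. On that basis compound 4 is expected to give about 30000 nM, within a range from 10000 nM to 100000 nM, and most probably to be reported as a limit rather than a number. The expected step that the limit leaves unreadable from compound 1 to compound 4 in this assay is none beyond the scatter.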

Compound 4, half-maximal inhibitory concentration: > 20000 nM
Compound 4 gave a limit, no number; the forecaster's own chance of this, stated with the estimate: 85%; the middle value is on the limit's open side.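

In this assay compound 4 gives > 20000 nM, a limit of the assay and not a number. Compound 1 also stands at a limit, so no step can be read between compound 1 and compound 4. The compounds shown leave open how far any of them lies past that limit, for all share it: the limit of > 20000 nM in this assay, at which 4 of the 4 values shown sit.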